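The source may hold more compounds than are shown below. What is called first, only, known or untested is meant among the compounds shown, and "the series" means these compounds.

Series values in a functional assay on PC-3 cells (Homo sapiens) for inhibition, read by sulforhodamine B assay; on this read-out higher numbers stand for weaker inhibition of growth and lower numbers for stronger inhibition of growth:
- compound 1 `Cc1ccc2[nH]c(-c3ccc(-c4ccc(-c5cccc(Cl)c5)cc4)cc3)nc2c1`: 2670 nM
- compound 2 `COc1cc(-c2ccc(-c3ccc(-c4nc5cc(C)ccc5[nH]4)cc3)cc2)cc(OC)c1OC`: 180 nM
- compound 3 `FC(F)(F)c1ccc(-c2ccc(-c3ccc(-c4nc5ccccc5[nH]4)cc3)cc2)cc1`: 45200 nM

Compound 3 has the highest number of the three, beyond the scatter of both others. Compound 4 `CN(C)c1ccc(-c2ccc(-c3ccc(-c4nc5ccccc5[nH]4)cc3)cc2)cc1` differs from compound 3 by one change. That change is dimethylamino in place of trifluoromethyl on an aromatic carbon, para to a large group. Among the measured compounds shown here, no measured pair differs in one place only, so the size of this step has no direct precedent. For the measured compounds named here, the only guide is the spread of the series, with compound 1 at 2670 nM and compound 2 at 180 nM. In this assay the expected size is a 23-fold lower number from compound 3 to compound 4 (1.35 log units; beyond the scatter), a drop beyond the scatter. For compound 4 the estimated value is 2000 nM, with an expected range of 200 nM to 20000 nM.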

Compound 4, concentration for 50% growth inhibition: 100000 nM
The estimate for compound 4 lay 50-fold (1.70 log units) below the measured number; the measured number lies above the stated range.
By their numbers in this assay, from the lowest: compound 2; then compound 1; then compound 3; then compound 4.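

In this assay, this position now has its first direct step: dimethylamino in place of trifluoromethyl on an aromatic carbon, para to a large group, gives a 2.2-fold higher number from compound 3 to compound 4 (0.34 log units; beyond the scatter). This is a modest weakening of growth inhibition, although the change replaces a group with no hydrogen-bond acceptor by one with a hydrogen-bond acceptor. No measurement available gives a cause for this step.

On these data alone, whether a primary amine, a carboxylic acid or a longer alkyl chain at this carbon would move the number further stays open. So does whether the same exchange gives a similar step on the core of compound 1.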